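Swapping a Carbamate for a Methylpyridine on the Ring Amine

The compounds below may be only part of what the source reports. "The series", "measured", "known", "first", "only" and "open" are said of these compounds alone.

compound 1 `CC(C)OC(=O)N1CCC(n2ncc3cc(-c4cc(F)c(C(N)=O)cc4F)ncc32)CC1`: 52 nM
compound 2 `CC(C)COC(=O)N1CCC(n2ncc3cc(-c4ccc(S(C)(=O)=O)cc4)ncc32)CC1`: 11 nM

In a functional assay on HEK293 cells for agonist activity at Glucose-dependent insulinotropic receptor (Homo sapiens), read by cAMP accumulation, with a stated time of 30 min (on this read-out lower numbers stand for an effect already at smaller amounts and higher numbers for an effect only at larger amounts of compound), compound 2 gives 11 nM, the lowest of the two numbers. Compound 1 gives 52 nM, a gap beyond the scatter. Compound 3 `Cc1ccc(N2CCC(n3ncc4cc(-c5ccc(S(C)(=O)=O)cc5)ncc43)CC2)nc1` differs from compound 2 by 5-methylpyridin-2-yl in place of isobutoxycarbonyl on an amine nitrogen in a ring. Going by the values given here, no measured pair isolates this change, so its size is uncertain. A modest weakening is expected, a 2.7-fold higher number from compound 2 to compound 3 (0.44 log units; beyond the scatter), with the range kept wide. Compound 3 is estimated at 30 nM, between 5 nM and 200 nM.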

Compound 3, half-maximal effective concentration: 30 nM
The estimate for compound 3 equals the measured number at the digits printed; low and high end bracket the measured number.
By their numbers in this assay, from the lowest: compound 2; then compounds 3 and 1 (each within the scatter of the next).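

In this assay, the amine nitrogen in the six-membered ring accepts an aromatic ring in place of the carbamate: 5-methylpyridin-2-yl for isobutoxycarbonyl gives a 2.7-fold higher number from compound 2 to compound 3 (0.44 log units; beyond the scatter), a modest loss. Activity therefore does not depend on a carbonyl at this position, as compound 3 still gives 30 nM in this range. Nothing available bears on the size of this step.

The compounds shown leave open what the methyl contributes to the pyridine. They also leave open how a pyrimidine, a plain pyridin-2-yl or an amide would behave on this nitrogen.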